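Shortening the chain on compound 2: expectation for compound 4

The source may hold more compounds than are shown below. What is called first, only, known or untested is meant among the compounds shown, and "the series" means these compounds.

In a functional assay on RKO cells (Homo sapiens) for inhibition, read by MTT assay, with a stated time of 48 h (a lower number here means a stronger inhibitor, a higher number a weaker inhibitor), compound 1 `C[Se]c1ccc(N(C)c2nc(C)nc3ccccc23)cc1C` gives 8 nM and compound 3 `Cc1nc(N(C)c2ccc([Se]C#N)c(F)c2)c2ccccc2n1` gives 8 nM. Compound 2 `COc1ccc(N(C)c2nc(C)nc3ccccc23)cc1OCCCCC[Se]C#N` gives 3560 nM in this assay, the highest number of the three and beyond the scatter from both others. Compound 4 `COc1ccc(N(C)c2nc(C)nc3ccccc23)cc1OCC[Se]C#N` differs from compound 2 in one place: a group of 3 heavy atoms (1 carbon, 1 nitrogen, 1 selenium; no ring) in place of a group of 6 heavy atoms (4 carbon, 1 nitrogen, 1 selenium; no ring), on a saturated chain carbon, two bonds along the chain from an oxygen on an aromatic ring. Within the data shown here, no measured pair shows this change, so the size of the step in this assay is open. Because compound 2 gives 3560 nM while the two others lie far lower, a downward step of moderate size is expected from compound 2 to compound 4, about a 2.4-fold lower number from compound 2 to compound 4 (0.38 log units; beyond the scatter), though a step within the scatter cannot be excluded. Compound 4 is expected to give about 1500 nM, between 300 nM and 8000 nM.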

Compound 4, half-maximal inhibitory concentration: 27 nM
For compound 4 the middle estimate is 56-fold (1.74 log units) above the measured one; the whole stated range lies above it.
By their numbers in this assay, from the lowest: compounds 1 and 3 (each within the scatter of the next); then compound 4; then compound 2.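

In this assay, this place on the chain proves highly sensitive: a group of 3 heavy atoms (1 carbon, 1 nitrogen, 1 selenium; no ring) in place of a group of 6 heavy atoms (4 carbon, 1 nitrogen, 1 selenium; no ring) gives a 130-fold lower number from compound 2 to compound 4 (2.12 log units; beyond the scatter). The high number of compound 2 therefore goes with the longer group, not with the rest of its structure, which compound 4 keeps. Nothing available explains the size of this step. Open, from the compounds shown here alone, is whether a chain of intermediate length gives an intermediate number, and whether an amine or a carboxylic acid at this place keeps the number of compound 4.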